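The compounds below may be only part of what the source reports. "The series", "measured", "known", "first", "only" and "open" are said of these compounds alone.

The series shares the core shown in compound 1 `Cn1nc(C(F)(F)F)cc1C(=O)Nc1ccc(S(=O)(=O)N2CCCC2)cc1O` and compound 2 `Cn1nc(C(F)(F)F)cc1C(=O)Nc1ccc(S(=O)(=O)N2CCC[C@H]2C(=O)OCc2ccccc2)cc1`, and all of it is compared in an ADME assay on Vero cells (Chlorocebus sabaeus) for cytotoxicity, read by MTT assay; on this read-out higher numbers stand for lower toxicity in this test and lower numbers for higher toxicity in this test. Compound 1 gives 288000 nM. Compound 2 gives 100000 nM. Compound 3 `Cn1nc(C(F)(F)F)cc1C(=O)Nc1ccc(S(=O)(=O)N2CCC[C@H]2C(=O)O)cc1` reaches only the limit of this assay, at > 300000 nM. Compound 3 therefore stands at the limit of > 300000 nM in this assay, at which 1 of the 3 values shown sits, with no exact number of its own. Within the data shown here, the one step that joins two measured compounds, an at least 3.0-fold higher number from compound 2 to compound 3 (0.47 log units; beyond the scatter), runs toward lower toxicity. The untested compound 4 `Cn1nc(C(F)(F)F)cc1C(=O)Nc1ccc(S(=O)(=O)N2CCCCC2)cc1` differs from compound 3 by piperidin-1-yl in place of 2-carboxypyrrolidin-1-yl on a sulfonyl sulfur. Among the measured compounds shown here, no measured step covers this exact change: the step into compound 3 removed a benzyl group and kept the acid, whereas the change to compound 4 takes away the acid together with its five-membered ring and puts a plain six-membered ring in its place. Compound 1 and compound 2, neither of which carries an acid, both sit at numbers this assay could resolve. Compound 4 is therefore expected to return to the measurable range, with an estimated step of an at least 1.6-fold lower number from compound 3 to compound 4 (0.22 log units; that floor lies within the scatter) toward somewhat higher toxicity. The estimated value for compound 4 is 180000 nM, within a range from 70000 nM to 350000 nM.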

Compound 4, half-maximal cytotoxic concentration: > 300000 nM
Compound 4: a limit, no number; the forecaster's own chance of this, stated with the estimate: 35%; middle value at least 1.6-fold (0.22 log units) away from the limit.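

In this assay compound 4 gives > 300000 nM, which is a limit and not a number. Compound 3 stands at a limit too, so no step between compound 3 and compound 4 can be read: the limit of > 300000 nM in this assay, at which 2 of the 4 values shown sit.

The compounds shown leave open whether piperidin-1-yl and 2-carboxypyrrolidin-1-yl on the sulfonyl sulfur differ at all in this assay.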